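The source may hold more compounds than are shown below. What is called first, only, known or untested is meant among the compounds shown, and "the series" means these compounds.

Measured so far in a functional assay on LS174T cells (Homo sapiens) for inhibition, with a stated time of 4 days, tested at 1 uM; on this read-out higher numbers stand for a stronger effect at the one concentration tested and lower numbers for a weaker effect:

Compound 1 `Fc1cccc(F)c1C#Cc1cncc2ccccc12` gives 16.5%.
Compound 2 `Fc1cccc(F)c1C#Cc1cnc(Cl)c2ccccc12` gives 48.1%.
Compound 3 `Fc1cccc(F)c1C#Cc1ccnc2ccccc12` gives 15.4%.

Compound 1 and compound 2 share a core and differ in one place: chloro in place of hydrogen on an aromatic carbon. This change made the step of a number 31.6 percentage points higher from compound 1 to compound 2 (beyond the scatter). Compound 3 has the same atoms as compound 1, joined differently; the difference between the two cores is not broken down here. In this assay the numbers of compound 1 and compound 3 lie within the scatter of each other.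

Compound 4 `Fc1cccc(F)c1C#Cc1ccnc2cc(Cl)ccc12` has not yet been measured. It differs from compound 3 by chloro in place of hydrogen on an aromatic carbon. This is the same kind of change as that from compound 1 to compound 2, but not the same: there the chloro entered on a six-membered aromatic ring with one nitrogen, next to the ring nitrogen, ortho to a fused ring, meta to a fused ring and para to a large group; here it enters on a six-membered aromatic ring of carbon only, meta to a fused ring and para to a fused ring. Because of the large step of a number 31.6 percentage points higher from compound 1 to compound 2 (beyond the scatter), a rise is also expected for compound 4. The surroundings of the chloro differ, though, so for compound 4 the expected step is a number 14.6 percentage points higher from compound 3 to compound 4 (beyond the scatter). Compound 4 is estimated at 30%, between 8% and 58%.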

Compound 4, a percentage reported as inhibition, at one concentration (the size of the read-out at that concentration, not a potency): 36%
Compound 4: middle estimate off by 6 percentage points, on the low side; low and high end bracket the measured number.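

On a second core, chloro in place of hydrogen on an aromatic carbon again gave a number 20.6 percentage points higher from compound 3 to compound 4 (beyond the scatter) in this assay. Set beside the earlier step, the size of this rise does not differ beyond the usual scatter: the same change on two cores in this assay, a number 31.6 percentage points higher (beyond the scatter) from compound 1 to compound 2 and a number 20.6 percentage points higher (beyond the scatter) from compound 3 to compound 4, 11 percentage points apart, within the scatter of two such steps. This shows that in these two pairs the change carried over from one core to the other in direction and in comparable size, even though the chloro sits on a different kind of ring in each; it does not show why the number rises, and two pairs cannot promise the same gain on a further core or with chloro at another place.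

The compounds shown leave open whether another group in place of the chloro, such as a methyl, a methoxy or an amine, would give a similar rise. They also leave open how much the fluoro groups contribute, and, as each number gives the size of the effect at a single concentration, whether the effect of any of these compounds would be stronger or weaker at another concentration.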